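Swapping one fluorinated phenyl group for another

The source may report more compounds than this note shows. Statements on the series, on what has been measured and on what is new or still open speak of the compounds shown alone.

Measured in a functional assay with Homo sapiens as the target (on this read-out higher numbers stand for weaker inhibition and lower numbers for stronger inhibition), so far:
compound 1 `CC(C)[C@H](NC(=O)COc1cccc2ccccc12)C(=O)N[C@@H](CC(=O)O)C(=O)COc1ccc(C(F)(F)F)cc1` gives 12300 nM
compound 2 `CC(C)[C@H](NC(=O)COc1cccc2ccccc12)C(=O)N[C@@H](CC(=O)O)C(=O)COc1cc(F)cc(F)c1` gives 15900 nM
compound 3 `CC(C)[C@H](NC(=O)COc1cccc2ccccc12)C(=O)N[C@@H](CC(=O)O)C(=O)COc1ccc(F)c(F)c1F` gives 20600 nM

Compound 3 (20600 nM) stands level with the other two, since all three values lie within the usual scatter of one another. Compound 4 `CC(C)[C@H](NC(=O)COc1cccc2ccccc12)C(=O)N[C@@H](CC(=O)O)C(=O)COc1c(F)c(F)cc(F)c1F` differs from compound 3 in one place, on an oxygen on a saturated carbon: 2,3,5,6-tetrafluorophenyl in place of 2,3,4-trifluorophenyl on an oxygen on a saturated carbon. Three earlier swaps of this same group bear on the change. They gave a 1.3-fold higher number from compound 1 to compound 2 (0.11 log units; within the scatter), then a 1.3-fold higher number from compound 2 to compound 3 (0.11 log units; within the scatter), and a 1.7-fold higher number from compound 1 to compound 3 (0.22 log units; within the scatter). From the compounds shown here alone, none of these exceeded the scatter, so no clear step is expected in this assay here, and the direction stays open. The estimated step is a 1.3-fold lower number from compound 3 to compound 4 (0.11 log units; within the scatter) as a best guess. For compound 4 the expected value is 16000 nM with an estimated range from 7000 nM to 34000 nM as the likely span.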

Compound 4, half-maximal inhibitory concentration: 6250 nM
For compound 4 the middle estimate is 2.6-fold (0.41 log units) above the measured one, and the stated range ends above it.
By their numbers in this assay, from the lowest: compounds 4, 1, 2 and 3 (each within the scatter of the next, the first and the last beyond it).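

Changes at this position can matter after all: the 2,3,5,6-tetrafluorophenyl group gives a 3.3-fold lower number from compound 3 to compound 4 (0.52 log units; beyond the scatter) and a 2.5-fold lower number from compound 2 to compound 4 (0.41 log units; beyond the scatter), the first steps in this series beyond the scatter. The 4-(trifluoromethyl)phenyl group remains level with it, with a 2.0-fold lower number from compound 1 to compound 4 (0.29 log units; within the scatter), which lies within the scatter. No supporting measurement here explains these steps. The compounds shown do not separate the effect of the extra fluorine from that of the new fluorine pattern. From the compounds shown here alone, how a phenyl group with no fluorine, or one carrying a nitrile or an amine, would compare also remains open.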